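Estimating a Methyl Addition in a Kinase Inhibitor Series

The source may hold more compounds than are shown below. What is called first, only, known or untested is meant among the compounds shown, and "the series" means these compounds.

Of the compounds shown here, three sharing a core have been measured in an assay on isolated protein for inhibition of proto-oncogene tyrosine-protein kinase receptor Ret (Homo sapiens), read by 33P incorporation, with stated times of 15 min and 40 min; on this read-out higher numbers stand for weaker inhibition and lower numbers for stronger inhibition. Compound 1 `O=C(Nc1ccc(Cl)cc1)Nc1ccc(Nc2ncnc3c2OCCN3)cc1` gives 3070 nM. Going by the values given here, compound 2 `O=C(Nc1ccc(Nc2ncnc3c2OCCN3)cc1)Nc1cc(Cl)cc(Cl)c1` gives 865 nM, and the step of a 3.5-fold lower number from compound 1 to compound 2 (0.55 log units; beyond the scatter) is the only one-place change among the measured pairs. Compound 3 `CC(C)(C)c1cc(NC(=O)Nc2ccc(Nc3ncnc4c3OCCN4)nc2)no1` gives 77 nM, the lowest number of the three, with compound 2 and compound 1 both standing clearly higher, beyond the scatter in each case.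

Compound 4 `Cc1nc(Nc2ncnc3c2OCCN3)ccc1NC(=O)Nc1cc(C(C)(C)C)on1` is the next member, and differs from compound 3 by methyl in place of hydrogen on an aromatic carbon. Among the compounds with values here, the single measured step, from compound 1 to compound 2, concerns the substitution pattern of the chlorophenyl on the urea and does not touch the ring that carries the new methyl, so it offers no direct guide to this change. Within the data shown here, with no measured precedent for adding a small group at this site, the expectation is a step of little size, within the scatter, in either direction, written here as a 1.1-fold lower number from compound 3 to compound 4 (0.04 log units; within the scatter). On that basis compound 4 is estimated to give 70 nM in this assay, with a range from 25 nM to 250 nM.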

Compound 4, half-maximal inhibitory concentration: 781 nM
The estimate for compound 4 lay 11-fold (1.05 log units) below the measured number; measured number outside the range, above it.
By their numbers in this assay, from the lowest: compound 3; then compounds 4 and 2 (each within the scatter of the next); then compound 1.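

In this assay, putting methyl in place of hydrogen on an aromatic carbon gives a 10-fold higher number from compound 3 to compound 4 (1.01 log units; beyond the scatter), a large step for a group of one heavy atom with no ring, no charge and no hydrogen-bond donors or acceptors. Going by these compounds alone, the one step among the earlier compounds concerned only the chlorophenyl on the urea, so it said nothing about the ring that carries the new methyl; this result shows that this place, next to the ring nitrogen, ortho to a large group and meta to a large group, does not tolerate even this small addition without a clear loss of inhibition. Nothing in the data at hand explains why this methyl has so large an effect on the number.

The compounds shown leave open whether this loss belongs to methyl in particular or would also follow with a fluorine atom, a chlorine atom, a methoxy group or an amine at the same carbon. They also leave open whether a longer chain such as ethyl would cost more or less than methyl does, and whether the same methyl would have a comparable effect in a compound carrying a chlorophenyl on the urea.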